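The source may report more compounds than this note shows. Statements on the series, on what has been measured and on what is new or still open speak of the compounds shown alone.

Measured so far in an ADME assay on S9 fraction from liver (Rattus norvegicus) for metabolic stability, read by LC-MS, using NADPH, with a stated time of 30 min; on this read-out higher numbers stand for a more stable compound and lower numbers for a less stable compound:
- compound 1 `CCCCCCCCc1ccc(OCC(=O)Cn2ncnn2)cc1`: < 5% (a limit of the assay, not a number)
- compound 2 `CCCCCCCCc1ccc(OCC(=O)Cn2nnc(-c3ccccc3)n2)cc1`: 33%
- compound 3 `CCCCCCCCc1ccc(OCC(=O)Cn2nnc(-c3ccc(C(=O)OC)cc3)n2)cc1`: 64%

Compound 3 holds the highest number in the series, and both steps leading to it lie beyond the scatter: a number at least 59 percentage points higher from compound 1 to compound 3 (beyond the scatter), and a number 31 percentage points higher from compound 2 to compound 3 (beyond the scatter). The series also shows a number at least 28 percentage points higher from compound 1 to compound 2 (beyond the scatter).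

Compound 4 `CCCCCCCCc1ccc(OCC(=O)Cn2nnc(-c3ccc(S(=O)(=O)N(C)C)cc3)n2)cc1` differs in one place only: dimethylsulfamoyl in place of methoxycarbonyl on an aromatic carbon. Dimethylsulfamoyl stands in place of methoxycarbonyl on an aromatic carbon, para to a large group.

Among the compounds with values here, no measured step exchanges one such group for another. The closest evidence is a number 31 percentage points higher from compound 2 to compound 3 (beyond the scatter), where methoxycarbonyl takes the place of hydrogen. That step shows that a group at this place can shift the result in this assay considerably, but not what a different group would do there. Compound 4 keeps a group at this place, so it is expected to stay closer to compound 3 than to compound 2, although a fall towards compound 2 cannot be excluded.

The expected change is a number 2 percentage points lower from compound 3 to compound 4 (within the scatter), which would lie within the scatter, with neither direction favoured. Compound 4 is estimated at 62%, with an expected range from 40% to 85%.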

Compound 4, percent of the compound remaining: 65%
Estimate against measurement, compound 4: 3 percentage points below; the range from low to high includes it.
By their numbers in this assay, from the lowest: compound 2; then compounds 3 and 4 (each within the scatter of the next). At a limit, below all of these: compound 1.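

In this assay, within the data shown here, the one exchange of a group for another at this place, on an aromatic carbon para to a large group, gives a number 1 percentage points higher from compound 3 to compound 4 (within the scatter), so this pair does not separate dimethylsulfamoyl from methoxycarbonyl, even though the entering group is larger and holds sulfur and nitrogen. Set against the plain phenyl of compound 2, dimethylsulfamoyl gives a number 32 percentage points higher from compound 2 to compound 4 (beyond the scatter), a step of the same order as a number 31 percentage points higher from compound 2 to compound 3 (beyond the scatter), so the rise seen earlier is not tied to methoxycarbonyl alone but is shared by these two groups. Against compound 1 the step is a number at least 60 percentage points higher from compound 1 to compound 4 (beyond the scatter), and its size is only a bound, as one end of it is a limit of the assay and not a number: the limit of < 5% in this assay, at which 1 of the 4 values shown sits.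

On these data alone, what an amine or a carboxylic acid at this place would give stays open, as does whether a small group such as methyl would hold the level shared by compound 3 and compound 4. Also open, as far as these compounds go, is whether that level would persist with a shorter chain in place of the octyl chain.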